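Selenoether and alkyne analogues in a Jurkat cytotoxicity assay

This account rests on a few compounds, and the source may have more. Where it says the series, first, only, none or still open, it means among the compounds named here.

Values in a functional assay on Jurkat cells (Homo sapiens) for cytotoxicity, read by MTT assay, with a stated time of 24 h; a lower number here means that less compound is needed, a higher number that more compound is needed for the effect:
compound 1 `CCOC(=O)c1cc([Se]c2ccc(OC)cc2)c2cc(OC)ccc2n1`: 82500 nM
compound 2 `CCOC(=O)c1cc([Se]c2ccccc2)c2cc(Cl)ccc2n1`: 53000 nM
compound 3 `CCOC(=O)c1cc(C#CCCO)c2cc(OC)ccc2n1`: 123000 nM

Compound 3 has the highest of the three numbers in this assay. Compound 1 sits within the scatter of compound 3; compound 2 gives a lower number than compound 3, beyond the scatter. Compound 4 `CCOC(=O)c1cc([Se]c2ccccc2)c2cc(OC)ccc2n1` has not yet been measured in this assay. It differs from compound 3 in one place: a group of 7 heavy atoms (6 carbon, 1 selenium; one six-membered aromatic ring of carbon only) in place of a group of 5 heavy atoms (4 carbon, 1 oxygen; no ring), on an aromatic carbon. Within the data shown here, no pair of measured compounds differs in a single place, so no measured step can be carried over. Both compound 1 and compound 2 carry a selenium-linked aromatic ring and neither gives a number above that of compound 3. A small step downward is expected a 1.9-fold lower number from compound 3 to compound 4 (0.28 log units; within the scatter), most likely within the scatter. Compound 4 is estimated at 65000 nM, with a range from 30000 nM to 140000 nM.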

Compound 4, half-maximal effective concentration: 102000 nM
Beside the measured number, compound 4's estimate is 1.6-fold (0.20 log units) below it; measured number inside the range.
By their numbers in this assay, from the lowest: compounds 2, 1, 4 and 3 (each within the scatter of the next, the first and the last beyond it).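

In this assay, the position opposite the ring nitrogen takes the selenium-linked aromatic ring in place of 4-hydroxybut-1-yn-1-yl without a change beyond the scatter (a 1.2-fold lower number from compound 3 to compound 4 (0.08 log units; within the scatter)). The two other single changes also stay within the scatter: methoxy in place of chloro (a 1.9-fold higher number from compound 2 to compound 4 (0.28 log units; within the scatter)) and hydrogen in place of methoxy (a 1.2-fold higher number from compound 1 to compound 4 (0.09 log units; within the scatter)). No supporting data explain these results.

From the compounds shown here alone, it remains open whether an amine or a carboxylic acid at this position, or a longer chain, would move the number beyond the scatter.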